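A few compounds are considered here, and "the series" means these few. Any claim that something is new, unique, unknown or untested is made for them only; others in the source may bear on it.

In a functional assay on HTB-54 cells (Homo sapiens) for cytotoxicity, read by MTT assay, with a stated time of 72 h (a higher number here means a weaker inhibitor of growth, a lower number a stronger inhibitor of growth), compound 1 `CCCCC[Se]c1nc(NCc2ccc(SC)cc2)c2ccccc2n1` gives 40400 nM. Compound 2 `CSc1ccc(CNc2nc([SeH])nc3ccccc23)cc1` is the parent of that pair, and in this assay compound 2 gives 45500 nM. The change between them is pentyl in place of hydrogen on a selenium, and it made the step of a 1.1-fold lower number from compound 2 to compound 1 (0.05 log units; within the scatter). Compound 3 `Nc1nc([SeH])nc2ccccc12` shares a core with compound 2, but how the two cores differ is not broken down here; in this assay compound 3 gives 40 nM, the lowest of the three numbers. Compound 4 `CCCCC[Se]c1nc(N)c2ccccc2n1` has not yet been measured. It differs from compound 3 by pentyl in place of hydrogen on a selenium, the same change that separates compound 2 from compound 1, at a place described in the same words. Since that change gave a 1.1-fold lower number from compound 2 to compound 1 (0.05 log units; within the scatter), a step of similar size is expected here, namely a 1.4-fold higher number from compound 3 to compound 4 (0.14 log units; within the scatter). Compound 4 is therefore estimated at 55 nM, with a plausible range from 15 nM to 300 nM.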

Compound 4, concentration for 50% growth inhibition: 34600 nM
Compound 4: middle estimate off by 630-fold (2.80 log units), on the low side; measured number above the stated range.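

In this assay, pentyl in place of hydrogen on a selenium did not carry from one core to the other: it gave an 870-fold higher number from compound 3 to compound 4 (2.94 log units; beyond the scatter), whereas on the other core it gave a 1.1-fold lower number from compound 2 to compound 1 (0.05 log units; within the scatter). The two steps differ by more than repeated measurements would explain: the same change on two cores in this assay, a 1.1-fold lower number (0.05 log units; within the scatter) from compound 2 to compound 1 and an 870-fold higher number (2.94 log units; beyond the scatter) from compound 3 to compound 4, 970-fold (2.99 log units) apart, beyond the scatter of two such steps This shows that the size of the step depended on the core in these two pairs, but it does not show which difference between the cores is responsible, and two pairs set no rule for any further core.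

The compounds shown leave open whether a methyl or a longer chain such as octyl on the selenium of the core of compound 3 would give a step like that of pentyl. They also leave open whether an amine or a carboxylic acid at the end of the chain would change that step.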